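A few compounds are considered here, and "the series" means these few. Any claim that something is new, unique, unknown or untested is made for them only; others in the source may bear on it.

Three compounds share one core and differ only in the aromatic group attached to it: compound 1 `C/C(=C\c1cc(-c2ccc(C)cc2)cs1)C(N)=O`, compound 2 `C/C(=C\c1nc(-c2ccccc2)cs1)C(N)=O` and compound 3 `C/C(=C\c1nc(-c2ccc(C)cc2)cs1)C(N)=O`. In an ADME assay on NIH3T3 cells (Mus musculus) for cytotoxicity, read by CCK-8 assay, with a stated time of 24 h (a higher number here means a weaker inhibitor, a lower number a stronger inhibitor), compound 1 gives only a limit of the assay, > 50000 nM. Compound 2 likewise gives a limit, > 50000 nM. Compound 3 also gives a limit, > 50000 nM. Among the compounds with values here, the one single-point change among them, a step that the two limits leave unreadable from compound 2 to compound 3, therefore cannot be sized because of the limit of > 50000 nM in this assay, at which 3 of the 3 values shown sit. Compound 3 thus stands at the limit, with nothing shown to set it apart from the other two.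

The next compound, compound 4 `C/C(=C\c1nc(-c2ccc(F)cc2)cs1)C(N)=O`, differs from compound 3 in one place: fluoro in place of methyl on an aromatic carbon. Within the data shown here, no measured step bears readably on this change, as every value so far sits at the limit. The expected step from compound 3 to compound 4 is a step that the limit leaves unreadable from compound 3 to compound 4, which is not beyond the scatter. Compound 4 is therefore expected to give 80000 nM, with a range from 30000 nM to 300000 nM, most likely again as a limit.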

Compound 4, half-maximal inhibitory concentration: > 50000 nM
Compound 4 gave a limit, no number; the forecaster's own chance of this, stated with the estimate: 85%; the middle value lies beyond the limit too.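

Compound 4 adds no readable step to compound 2 or compound 3, because each of these compounds, like compound 1, gives only a limit and no number: the limit of > 50000 nM in this assay, at which 4 of the 4 values shown sit.

In this assay the compounds shown leave open whether changing the aromatic group alters the value at all.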